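The compounds below may be only part of what the source reports. "The series", "measured", "known", "first", "only" and "open" are said of these compounds alone.

Compound 1 `COc1ccc(OCCCON2C(N)=NC(N)=NC23CCOCC3)cc1` is tested in a functional assay on A549 cells (Homo sapiens) for antiproliferative activity, read by MTT assay, with a stated time of 72 h (a lower number here means a stronger inhibitor, a higher number a weaker inhibitor), where compound 1 gives 660 nM. Compound 2 `NC1=NC2(CCSCC2)N(OCCCOc2ccc(Br)cc2)C(N)=N1`, which carries a different core, gives in this assay a value of 740 nM, and this sits with the number of compound 1 within the usual scatter of repeated measurements. Compound 3 `NC1=NC2(CCSCC2)N(OCCCOc2cc(Cl)c(Cl)cc2Cl)C(N)=N1`, in contrast, reaches only the limit of > 100000 nM in this assay, so that no number is known for compound 3, only (the limit of > 100000 nM in this assay, at which 1 of the 3 values shown sits). Going by the values given here, the one step measured on a single change, an at least 130-fold higher number from compound 2 to compound 3 (2.13 log units; beyond the scatter), is therefore large.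

Compound 4 `NC1=NC2(CCOCC2)N(OCCCOc2cccc(Cl)c2)C(N)=N1` keeps the core of compound 1 and differs from it by 3-chlorophenyl in place of 4-methoxyphenyl on an oxygen on a saturated carbon. Among the compounds with values here, the only measured step that touches a halogenated phenyl group is the one from compound 2 to compound 3, and it moved three chlorines onto the ring at once, whereas compound 4 carries a single chlorine, and compound 2 with its 4-bromophenyl stays near compound 1. A small loss is expected, a 1.8-fold higher number from compound 1 to compound 4 (0.26 log units; within the scatter), and compound 4 is estimated at 1200 nM in this assay, between 400 nM and 5000 nM.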

Compound 4, half-maximal inhibitory concentration: 150 nM
Compound 4: the middle estimate sits 8.0-fold (0.90 log units) above what was measured; the measured number lies below the stated range.
By their numbers in this assay, from the lowest: compound 4; then compounds 1 and 2 (each within the scatter of the next). At a limit, above all of these: compound 3.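

In this assay, the change at this place on the core of compound 1 gives a 4.4-fold lower number from compound 1 to compound 4 (0.64 log units; beyond the scatter), the only single change shown that lowers the number. Until now, a halogenated phenyl group had appeared in a single-change step only as the large loss at compound 3, so compound 4 shows that chlorine on this ring is compatible with a stronger inhibitor, while compound 3 remains the case against any general rule. Nothing measured here gives a reason for the step.

On these data alone, what a 3-methoxyphenyl or a 4-chlorophenyl group would give on the core of compound 1 remains open, so the effect of the chlorine cannot be separated from that of its place on the ring. Also open, as far as these compounds go, are whether 3-chlorophenyl gives a similar step on the core of compound 2, and how an amine or a carboxylic acid on the ring would fare.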